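Aromatic substituent changes in an antiproliferative ketone series

The source may hold more compounds than are shown below. What is called first, only, known or untested is meant among the compounds shown, and "the series" means these compounds.

Measured in a functional assay on HeLa cells (Homo sapiens) for antiproliferative activity, read by resazurin assay; a lower number here means a stronger inhibitor, a higher number a weaker inhibitor:
- compound 1 `CCSC(=S)SCC(=O)c1ccc(C)cc1`: 3980 nM
- compound 2 `CCSC(=S)SCC(=O)c1ccc(S(N)(=O)=O)cc1`: 20000 nM
- compound 3 `CCSC(=S)SCC(=O)c1ccc(NS(C)(=O)=O)cc1`: 39800 nM

Compound 3 carries the highest number of the three, but its gap to compound 2 is within the scatter, a 2.0-fold higher number from compound 2 to compound 3 (0.30 log units; within the scatter), so the two cannot be ordered. Both stand beyond the scatter from the methyl-bearing compound: a 10-fold higher number from compound 1 to compound 3 (1.00 log units; beyond the scatter) and a 5.0-fold higher number from compound 1 to compound 2 (0.70 log units; beyond the scatter). Within these three, every departure from methyl on the aromatic carbon has raised the number.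

Compound 4 `CCSC(=S)SCC(=O)c1ccc(N(CC)CC)cc1` is not yet measured. Its change from compound 3 is diethylamino in place of methanesulfonamido on an aromatic carbon. Going by the values given here, no measured step introduces diethylamino, so the only bearing comes from the step that brought methanesulfonamido in, a 10-fold higher number from compound 1 to compound 3 (1.00 log units; beyond the scatter), read in reverse: removing that group is expected to lower the number, while how far the diethylamino group itself moves the value is not known from these data. The expectation is a step beyond the scatter toward a lower number, a 6.6-fold lower number from compound 3 to compound 4 (0.82 log units; beyond the scatter), landing between the region of compound 1 and that of compound 3. For compound 4 the estimate in this assay is 6000 nM, with a range from 1500 nM to 25000 nM.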

Compound 4, half-maximal inhibitory concentration: 3160 nM
Beside the measured number, compound 4's estimate is 1.9-fold (0.28 log units) above it; the range from low to high includes it.
By their numbers in this assay, from the lowest: compounds 4 and 1 (each within the scatter of the next); then compounds 2 and 3 (each within the scatter of the next).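

The opening note that every departure from methyl on the aromatic carbon raises the number no longer holds: in this assay, a 1.3-fold lower number from compound 1 to compound 4 (0.10 log units; within the scatter), so diethylamino and methyl cannot be ordered at this position. Methanesulfonamido and diethylamino each count 5 heavy atoms, yet a 13-fold lower number from compound 3 to compound 4 (1.10 log units; beyond the scatter), and the exchange for sulfamoyl gives a comparable picture, with a 6.3-fold lower number from compound 2 to compound 4 (0.80 log units; beyond the scatter), so at this place on the aromatic ring the identity of the group separates compound 1 and compound 4 from compound 2 and compound 3, and an equal heavy-atom count does not hold the values together. Nothing available on the compounds accounts for this split, and the difference between the groups remains an observation without an assigned cause.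

Open, on these data alone, is whether an unsubstituted amino group or a dimethylamino group would stay with compound 1 and compound 4, and whether a longer chain on the nitrogen would keep the number there. A carboxylic acid at the same place would test whether the higher numbers of compound 2 and compound 3 extend to a group without sulfur-bearing sulfonyl atoms.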